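Swapping a piperazinylmethyl arm for a chlorostyryl group

The source may report more compounds than this note shows. Statements on the series, on what has been measured and on what is new or still open speak of the compounds shown alone.

Of the compounds shown here, three sharing one core have been measured in a functional assay on HeLa cells (Homo sapiens) for cytotoxicity, read by MTT assay, with a stated time of 72 h; on this read-out higher numbers stand for weaker inhibition and lower numbers for stronger inhibition. Compound 1 `CN1CCN(Cc2nnc(-c3cc(S(N)(=O)=O)c(SCc4ccccc4)cc3Cl)o2)CC1` gives 75000 nM and stands second highest of the three numbers. Its nearest neighbour is compound 2 `CCOC(=O)c1cn(Cc2nnc(-c3cc(S(N)(=O)=O)c(SCc4ccccc4)cc3Cl)o2)nn1`, which gives 122000 nM; the step of a 1.6-fold higher number from compound 1 to compound 2 (0.21 log units; within the scatter) lies within the scatter. The furthest is compound 3 `NS(=O)(=O)c1cc(-c2nnc(Cn3cc(-c4ccccc4)nn3)o2)c(Cl)cc1SCc1ccccc1`, which gives 7000 nM; the step of an 11-fold lower number from compound 1 to compound 3 (1.03 log units; beyond the scatter) is beyond the scatter, and the step of a 17-fold lower number from compound 2 to compound 3 (1.24 log units; beyond the scatter) is larger still.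

Compound 4 `NS(=O)(=O)c1cc(-c2nnc(/C=C/c3ccc(Cl)cc3)o2)c(Cl)cc1SCc1ccccc1` has not yet been measured in this assay. Relative to compound 1 it differs as follows: 2-(4-chlorophenyl)ethenyl in place of (4-methylpiperazin-1-yl)methyl on an aromatic carbon.

Among the measured compounds shown here, two measured steps bear on this change. For the measured compounds named here, the step of an 11-fold lower number from compound 1 to compound 3 (1.03 log units; beyond the scatter) shows that replacing the 4-methylpiperazin-1-yl group with a phenyl-bearing group gave a markedly lower number, and the step of a 17-fold lower number from compound 2 to compound 3 (1.24 log units; beyond the scatter) again points to the phenyl-bearing compound 3 as the one with the lowest number in this set. Because compound 3 gives 7000 nM and compound 4 likewise carries an aromatic ring of carbon only in this position, a lower number than compound 1 is expected for compound 4, with the step of a 9.4-fold lower number from compound 1 to compound 4 (0.97 log units; beyond the scatter) estimated. Compound 4 is therefore expected to give 8000 nM, within a range from 2000 nM to 30000 nM.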

Compound 4, half-maximal inhibitory concentration: 40000 nM
Compound 4: middle estimate off by 5.0-fold (0.70 log units), on the low side; the measured number lies above the stated range.
By their numbers in this assay, from the lowest: compound 3; then compounds 4, 1 and 2 (each within the scatter of the next, the first and the last beyond it).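

In this assay, a carbon-only aromatic ring at this position is not enough to reach the low number of compound 3: there is a 5.7-fold higher number from compound 3 to compound 4 (0.76 log units; beyond the scatter) and only a 1.9-fold lower number from compound 1 to compound 4 (0.27 log units; within the scatter) so the 2-(4-chlorophenyl)ethenyl group cannot be told apart from the (4-methylpiperazin-1-yl)methyl group it replaces. Among the compounds shown here, the new group does separate from the triazole arm that carries ethoxycarbonyl, with a 3.1-fold lower number from compound 2 to compound 4 (0.48 log units; beyond the scatter) and so compound 3 remains the only compound whose number lies beyond the scatter from those of all the others. No measurement given here accounts for these differences.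

The compounds shown leave open which change matters most in the step from compound 3 to compound 4, where the chlorine, the double bond and the loss of the 1H-1,2,3-triazole all arrive together. They also leave open how an unsubstituted 2-phenylethenyl group, a saturated 2-(4-chlorophenyl)ethyl chain or a carboxylic acid in place of the ethoxycarbonyl would read at this position.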